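This account rests on a few compounds, and the source may have more. Where it says the series, first, only, none or still open, it means among the compounds named here.

Of the compounds shown here, three have been measured.
Compound 1 `N[C@H]1CC[C@H](Nc2c(C(=O)NCc3ccccn3)nc(Br)c3cccnc23)CC1`: in a functional assay on HEY cells (Homo sapiens) for cytotoxicity, read by MTT assay, with a stated time of 72 h (on this read-out lower numbers stand for stronger inhibition and higher numbers for weaker inhibition), compound 1 reaches only the limit > 20000 nM, which is not a number.
Compound 2 `N[C@H]1CC[C@H](Nc2c(C(=O)NCc3cccc(C(F)(F)F)c3)nc(Br)c3cccnc23)CC1`: in this assay compound 2 gives 12000 nM.
Compound 3 `N[C@H]1CC[C@H](NC(=O)c2nc(Br)c3cccnc3c2NCc2ccc(F)cc2)CC1`: in this assay compound 3 gives 7100 nM.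

Compound 2 and compound 3 give numbers that sit within the usual scatter of each other, so neither can be called stronger. Compound 1 sits at the limit of > 20000 nM in this assay, at which 1 of the 3 values shown sits.

Compound 4 `N[C@H]1CC[C@H](Nc2c(C(=O)NCc3ccccc3)nc(Br)c3cccnc23)CC1` differs from compound 2 in one place: hydrogen in place of trifluoromethyl on an aromatic carbon. For the measured compounds named here, the only measured step touching the same benzylic position is an at least 1.6-fold lower number from compound 1 to compound 2 (0.22 log units; that floor lies within the scatter), where the trifluoromethyl-bearing ring entered in place of pyridin-2-yl; its floor lies within the scatter. Removing the trifluoromethyl while keeping the phenyl ring is therefore expected to shift the number little, and no step beyond the scatter is expected, so the estimated step is no change at the digits printed from compound 2 to compound 4 (within the scatter). Compound 4 is estimated at 12000 nM in this assay, with a range from 5000 nM to 30000 nM.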

Compound 4, half-maximal inhibitory concentration: 8000 nM
Compound 4: middle estimate off by 1.5-fold (0.18 log units), on the high side, and the stated range covers the measured number.
By their numbers in this assay, from the lowest: compounds 3, 4 and 2 (each within the scatter of the next). At a limit, above all of these: compound 1.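

In this assay, taking the trifluoromethyl off the ring gives a 1.5-fold lower number from compound 2 to compound 4 (0.18 log units; within the scatter), so this group is not needed for the activity seen with this benzyl amide. Phenyl in place of pyridin-2-yl gives an at least 2.5-fold lower number from compound 1 to compound 4 (0.39 log units; beyond the scatter), which is the first step at this position that lies beyond the scatter and points to the plain carbon ring as better tolerated here than the pyridine ring. The true size of that step is unknown, as compound 1 reaches a limit and not a number: the limit of > 20000 nM in this assay, at which 1 of the 4 values shown sits.

Still open, on these data alone, is whether a different group at the same ring carbon, such as a methoxy group, a chlorine or an amine, would move the number beyond the scatter. As far as these compounds go, it is also open whether a longer chain between the amide nitrogen and the phenyl ring would be tolerated.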